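Chloro to bromo on a saturated carbon in two cores

This account rests on a few compounds, and the source may have more. Where it says the series, first, only, none or still open, it means among the compounds named here.

Compound 1 `ClCc1cn(Cc2ccccc2)nn1` gives 18 ug/mL in a functional assay on HeLa cells (Homo sapiens), read by colorimetric assay, with a stated time of 72 h; on this read-out higher numbers stand for an effect only at larger amounts of compound and lower numbers for an effect already at smaller amounts.
Compound 2 `BrCc1cn(Cc2ccccc2)nn1` gives 2 ug/mL in this assay.
Compound 3 `CC(=O)N[C@@H]1[C@@H](OC(C)=O)[C@H](OC(C)=O)[C@@H](COC(C)=O)O[C@H]1n1cc(CCl)nn1` gives 20 ug/mL in this assay.

Of the compounds shown here, three have been measured so far, and a fourth, compound 4 `CC(=O)N[C@@H]1[C@@H](OC(C)=O)[C@H](OC(C)=O)[C@@H](COC(C)=O)O[C@H]1n1cc(CBr)nn1`, awaits its number. Compounds 1 and 2 share one core and differ by a single change, (bromo in place of chloro on a saturated chain carbon bound to an aromatic carbon). That change brought a 9.0-fold lower number from compound 1 to compound 2 (0.95 log units; beyond the scatter), a step that lies beyond the usual scatter of this kind of measurement.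

Compound 3 carries a different core; how its core differs from that of compound 1 is not broken down here. Its value and that of compound 1 lie within the scatter of each other, so nothing can be said about their order.

Compound 4 is related to compound 3 by the same change that relates compound 2 to compound 1: bromo in place of chloro on a saturated chain carbon bound to an aromatic carbon. The place of the change is described in the same words in both pairs, so it is the same change, set on a different core.

Because compound 3 gives 20 ug/mL and compound 1 gives 18 ug/mL, two numbers within the scatter of each other, and because the change from compound 1 to compound 2 gave a 9.0-fold lower number from compound 1 to compound 2 (0.95 log units; beyond the scatter), a step of similar size is expected here, read as an 8.0-fold lower number from compound 3 to compound 4 (0.90 log units; beyond the scatter). Within the data shown here, the only basis for this is the one measured pair, so the expected range is kept wide. Compound 4 is therefore estimated to give 2.5 ug/mL in this assay, expected to fall between 1 ug/mL and 8 ug/mL.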

Compound 4, concentration for half-maximal effect: 20 ug/mL
Compound 4: the middle estimate sits 8.0-fold (0.90 log units) below what was measured; the measured number lies above the stated range.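

In this assay, putting bromo in place of chloro on the saturated chain carbon bound to an aromatic carbon brings no change at the digits printed from compound 3 to compound 4 (within the scatter), so on the core of compound 3 this swap leaves no measurable mark. This does not show why the two cores behave differently, since the cores differ in more than one place and the data do not say which part of them matters; nor does one pair on each core show how the swap would behave on any third core. What it does show is that, in this series, a step measured on one core cannot simply be carried to another, as the two steps themselves differ by more than repeat measurements would explain: the same change on two cores in this assay, a 9.0-fold lower number (0.95 log units; beyond the scatter) from compound 1 to compound 2 and no change at the digits printed (within the scatter) from compound 3 to compound 4, 9.0-fold (0.95 log units) apart, beyond the scatter of two such steps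

The compounds shown leave open how other groups on the same carbon would read on each core, for instance iodo, an amine or a longer chain in place of the halogen. They also leave open whether the bromo step would come back on a version of the core of compound 3 bearing free hydroxyl groups instead of its acetate esters.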